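A few compounds are considered here, and "the series" means these few. Any claim that something is new, unique, unknown or untested is made for them only; others in the source may bear on it.

In a functional assay on A549/CDDP cells (Homo sapiens) for antiproliferative activity, read by MTT assay, with a stated time of 72 h (on this read-out lower numbers stand for stronger inhibition and higher numbers for weaker inhibition), compound 1 `Cc1nc(C)c(/C=C/C(=O)/C=C/c2ccccc2O)nc1C` gives 3900 nM, compound 2 `COc1cccc(/C=C/C(=O)/C=C/c2nc(C)c(C)nc2C)c1O` gives 2190 nM and compound 3 `COc1ccc(/C=C/C(=O)/C=C/c2nc(C)c(C)nc2C)cc1OC` gives 2440 nM. These three values lie within the scatter of one another, so compound 1 stands level with both. Compound 4 `Cc1nc(C)c(/C=C/C(=O)/C=C/c2ccccc2)nc1C` differs from compound 1 as follows: hydrogen in place of hydroxy on an aromatic carbon. This is hydrogen in place of hydroxy on an aromatic carbon. Among the measured compounds shown here, the one measured step that bears on it, a 1.8-fold lower number from compound 1 to compound 2 (0.25 log units; within the scatter), is a different change, methoxy in place of hydrogen, and stays within the scatter. For the measured compounds named here, no measured pair removes the hydroxy, so no step beyond the scatter is expected in this assay. The expected step is a 1.2-fold higher number from compound 1 to compound 4 (0.06 log units; within the scatter), an estimate within the scatter. For compound 4 the estimated value is 4500 nM, with an expected range of 2000 nM to 10000 nM.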

Compound 4, half-maximal inhibitory concentration: 11900 nM
The estimate for compound 4 lay 2.6-fold (0.42 log units) below the measured number; measured number above the stated range.
By their numbers in this assay, from the lowest: compounds 2, 3 and 1 (each within the scatter of the next); then compound 4.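

Among the compounds shown here, replacing the hydroxy with hydrogen gives the first step beyond the scatter: in this assay there is a 3.1-fold higher number from compound 1 to compound 4 (0.48 log units; beyond the scatter). Compound 1, compound 2 and compound 3 lie within the scatter of one another, so only the 2-hydroxyphenyl to phenyl change separates a compound from its parent here. Nothing available explains this step.

Going by these compounds, whether this gain depends on hydroxy itself remains open. An amine or a fluorine on the same aromatic carbon would test whether other groups keep the lower number.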